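A few compounds are considered here, and "the series" means these few. Any claim that something is new, unique, unknown or untested is made for them only; others in the source may bear on it.

Of the compounds shown here, three built on a shared core have been measured in a functional assay on UACC-62 cells (Homo sapiens) for inhibition, read by sulforhodamine B assay, with a stated time of 48 h; on this read-out higher numbers stand for weaker inhibition of growth and lower numbers for stronger inhibition of growth. Compound 1 `COc1cc(OC)cc(-c2ccc(-c3ccc(C(=N)N)c(F)c3)s2)c1` gives 1440 nM. Compound 2 `N=C(N)c1ccc(-c2ccc(-c3ccc(Cl)cc3)s2)cc1F` gives 218 nM, and compound 3 `N=C(N)c1ccc(-c2ccc(-c3ccc(Cl)cc3)s2)cc1` gives 178 nM. Compound 1 thus shows the highest number of the three, and its steps to the other two lie beyond the scatter. The difference between the core of compound 1 and the core of compound 2 is not broken down here.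

Compound 2 and compound 3 differ in one place only: hydrogen in place of fluoro on an aromatic carbon This change gave a 1.2-fold lower number from compound 2 to compound 3 (0.09 log units; within the scatter), so the two values sit within the scatter of each other and no ordering between them can be claimed.

Compound 4 `COc1cc(OC)cc(-c2ccc(-c3ccc(C(=N)N)cc3)s2)c1` has not yet been measured in this assay. It differs from compound 1 in exactly the same way: hydrogen in place of fluoro on an aromatic carbon The group that leaves, the group that enters and the place where it happens are identical in both pairs, so this is the same change carried over to the core of compound 1.

Because the earlier step was a 1.2-fold lower number from compound 2 to compound 3 (0.09 log units; within the scatter), the step from compound 1 to compound 4 in this assay is expected to be about as small, a 1.1-fold lower number from compound 1 to compound 4 (0.04 log units; within the scatter). On that basis compound 4 is estimated to give 1300 nM, with a likely range from 600 nM to 2800 nM. The measurement itself will show whether this holds.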

Compound 4, concentration for 50% growth inhibition: 1870 nM
Compound 4: middle estimate off by 1.4-fold (0.16 log units), on the low side; low and high end bracket the measured number.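

On the core of compound 1, putting hydrogen in place of fluoro on the aromatic carbon gave a 1.3-fold higher number from compound 1 to compound 4 (0.11 log units; within the scatter) in this assay, so compound 1 and compound 4 cannot be ranked against each other. Set beside the same change on the other core, the two steps printed as going in opposite directions cannot be told apart, and they agree as far as this read-out can show: the same change on two cores in this assay, a 1.2-fold lower number (0.09 log units; within the scatter) from compound 2 to compound 3 and a 1.3-fold higher number (0.11 log units; within the scatter) from compound 1 to compound 4, 1.6-fold (0.20 log units) apart, within the scatter of two such steps This shows that in these two pairs the change carries from one core to the other without a step that stands clear of the scatter, so on either core the fluoro group could be kept or dropped with no visible difference in this read-out; it does not show that the change has no effect at all, since a small real shift could hide inside the scatter, and two pairs make no general rule for other cores.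

The compounds shown leave open whether a hydroxyl or a trifluoromethyl group at that same place would give a step beyond the scatter. Also open, as far as these compounds go, is whether the change would stay this small on a core carrying an amine or a carboxylic acid in place of the chloro group.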